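Moving the trifluoromethyl across the pendant phenyl of compound 3

The source may report more compounds than this note shows. Statements on the series, on what has been measured and on what is new or still open speak of the compounds shown alone.

In a functional assay on HCT-15 cells (Homo sapiens) for inhibition (a lower number here means a stronger inhibitor, a higher number a weaker inhibitor), compound 3 `Oc1cccc(-c2cc(-c3ccccc3C(F)(F)F)cc(-c3ccccc3O)n2)c1` gives 9010 nM, the higher of the two numbers in the series. Compound 1 `Oc1cccc(-c2cc(-c3ccccc3F)cc(-c3ccccc3O)n2)c1` gives 8470 nM, and the step of a 1.1-fold higher number from compound 1 to compound 3 (0.03 log units; within the scatter) lies within the scatter. Compound 2 `Oc1cccc(-c2cc(-c3ccc(F)cc3)cc(-c3ccccc3O)n2)c1` gives only a limit, > 50000 nM. Compound 4 `Oc1cccc(-c2cc(-c3ccc(C(F)(F)F)cc3)cc(-c3ccccc3O)n2)c1` arises through (4-(trifluoromethyl)phenyl in place of 2-(trifluoromethyl)phenyl on an aromatic carbon). The comparable move from 2-fluorophenyl to 4-fluorophenyl gave an at least 5.9-fold higher number from compound 1 to compound 2 (0.77 log units; beyond the scatter), and an at least 5.5-fold lower number from compound 2 to compound 3 (0.74 log units; beyond the scatter) points the same way, so the measured steps agree that the 4-substituted phenyl weakens inhibition. A step toward weaker inhibition of similar size is therefore expected, a 6.7-fold higher number from compound 3 to compound 4 (0.82 log units; beyond the scatter). For compound 4 the estimate is 60000 nM, spanning 15000 nM to 200000 nM, with a fair chance that only a limit is returned.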

Compound 4, half-maximal inhibitory concentration: > 50000 nM
Compound 4: only a limit was reported; the forecaster's own chance of this, stated with the estimate: 60%; the middle value does not contradict the limit.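

In this assay, moving trifluoromethyl on the phenyl opposite the ring nitrogen, from 2-(trifluoromethyl)phenyl to 4-(trifluoromethyl)phenyl, gives an at least 5.5-fold higher number from compound 3 to compound 4 (0.74 log units; beyond the scatter), so the weakening seen with fluoro also appears with a second substituent. Replacing 2-fluorophenyl with 4-(trifluoromethyl)phenyl gives an at least 5.9-fold higher number from compound 1 to compound 4 (0.77 log units; beyond the scatter). The step between the two 4-substituted compounds cannot be read, since compound 2 and compound 4 both return only a limit: the limit of > 50000 nM in this assay, at which 2 of the 4 values shown sit.

Open, as far as these compounds go, is how far apart compound 2 and compound 4 lie. Also open, from the compounds shown here alone, is whether an amine or a carboxylic acid in place of the trifluoromethyl of compound 3 would keep the inhibition.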